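This account rests on a few compounds, and the source may have more. Where it says the series, first, only, none or still open, it means among the compounds named here.

In a functional assay on HeLa cells (Homo sapiens) for inhibition, read by MTT assay, with a stated time of 4 days (a lower number here means a stronger inhibitor, a higher number a weaker inhibitor), compound 1 (`COc1cc(NC(C)CCCNC(=O)NNC(=O)Nc2ccc(Cl)c(C(F)(F)F)c2)c2ncccc2c1`) gives 17000 nM. Compound 3 (`COc1cc(NC(C)CCCNC(=O)NNC(=O)NCCNC(c2ccccc2)(c2ccccc2)c2ccccc2)c2ncccc2c1`) gives 10000 nM, which lies within the scatter of compound 1, so the two cannot be told apart here. Compound 2 (`COc1ccc(/C(=N/NC(=O)NCCCC(C)Nc2cc(OC)cc3cccnc23)c2ccccc2)cc1`) gives 129000 nM, a number beyond the scatter and higher than that of compound 1, which makes it the weaker inhibitor of that pair.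

Compound 4 (`COc1cc(NC(C)CCCNC(=O)NNC(=O)NC(CO)(CO)CO)c2ncccc2c1`) has not yet been measured. It carries 2-hydroxy-1,1-bis(hydroxymethyl)ethyl in place of 4-chloro-3-(trifluoromethyl)phenyl on an amide-type nitrogen. For the measured compounds named here, no two measured compounds differ in one place only, so the data offer no direct guide to this change. The only guide is the spread of values, in which compound 2 at 129000 nM shows that numbers well up from compound 1 do occur among these structures. A weakening beyond the scatter is expected, and the estimated step is a 3.2-fold higher number from compound 1 to compound 4 (0.51 log units; beyond the scatter). For compound 4, the expected value is 55000 nM, with an estimated range from 15000 nM to 200000 nM.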

Compound 4, half-maximal inhibitory concentration: > 250000 nM
Compound 4: only a limit was reported; the forecaster's own chance of this, stated with the estimate: 25%; at least 4.5-fold (0.65 log units) between middle value and limit.
By their numbers in this assay, from the lowest: compounds 3 and 1 (each within the scatter of the next); then compound 2. At a limit, above all of these: compound 4.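

Compound 1 and compound 4 differ only in the group on this amide-type nitrogen, so this pair gives the first direct reading of a single change among the compounds shown. Putting the ringless 2-hydroxy-1,1-bis(hydroxymethyl)ethyl in place of the aromatic 4-chloro-3-(trifluoromethyl)phenyl gives an at least 14-fold higher number from compound 1 to compound 4 (1.16 log units; beyond the scatter) and shows that the group on this nitrogen can shift the reading well beyond the scatter. In this assay, as far as these compounds go, compound 4 gives > 250000 nM as a limit of the assay and not a number, so the full size of the step stays unknown: the limit of > 250000 nM in this assay, at which 1 of the 4 values shown sits.

The compounds shown leave open which part of the change matters: the loss of the ring, the loss of the chlorine and trifluoromethyl, or the gain of the hydroxyl groups. A plain phenyl or a tert-butyl group on the same nitrogen would help separate these.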